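Compound 1 to compound 4: hydrogen for methyl

The compounds below may be only part of what the source reports. "The series", "measured", "known", "first", "only" and "open" are said of these compounds alone.

Measured in a functional assay on A549 cells (Homo sapiens) for cytotoxicity, read by MTT assay, with a stated time of 72 h; on this read-out lower numbers stand for stronger inhibition and higher numbers for weaker inhibition
Compound 1 `Cn1ccc2c(Oc3ccc(NC(=O)c4cc5cccnc5n(-c5ccc(F)cc5)c4=O)cc3F)ncnc21` gives 7320 nM
Compound 2 `Cn1ccc2c(Oc3ccc(NC(=O)c4cc5cccnc5n(-c5ccc(Cl)cc5)c4=O)cc3F)ncnc21` gives 55500 nM
Compound 3 `Cn1ccc2c(Oc3ccc(NC(=O)c4cc5cccnc5n(-c5ccc(C(F)(F)F)cc5Cl)c4=O)cc3F)ncnc21` gives "not active" (no number reported)

Compound 1 holds the lower of the two numbers, and compound 3 has no number. Compound 4 `O=C(Nc1ccc(Oc2ncnc3[nH]ccc23)c(F)c1)c1cc2cccnc2n(-c2ccc(F)cc2)c1=O` is still unmeasured and differs from compound 1 by hydrogen in place of methyl on an aromatic nitrogen. Among the compounds with values here, no measured step touches that place. The only one is a 7.6-fold higher number from compound 1 to compound 2 (0.88 log units; beyond the scatter) for chloro in place of fluoro on an aromatic carbon and so offers a rough size but no direction. A modest move toward a lower number in this assay is expected, though the direction is a weak guess. The expected step is a 2.4-fold lower number from compound 1 to compound 4 (0.39 log units; beyond the scatter) on this reading. Compound 4 is estimated at 3000 nM with an expected range from 600 nM to 20000 nM in these notes.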

Compound 4, half-maximal inhibitory concentration: 5290 nM
For compound 4 the middle estimate is 1.8-fold (0.25 log units) below the measured one; measured number inside the range.
By their numbers in this assay, from the lowest: compounds 4 and 1 (each within the scatter of the next); then compound 2.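

At this position, on an aromatic nitrogen of a five-membered aromatic ring, this assay separates hydrogen from methyl by no more than the usual scatter (a 1.4-fold lower number from compound 1 to compound 4 (0.14 log units; within the scatter)). The methyl is therefore not needed for the activity of compound 1 in this read-out, whereas chloro in place of fluoro on an aromatic carbon produced a step beyond the scatter (a 7.6-fold higher number from compound 1 to compound 2 (0.88 log units; beyond the scatter)). No supporting data are available to explain this result.

From the compounds shown here alone, whether an ethyl group or a longer chain bearing an amine on this nitrogen would fit the same picture remains open. Going by these compounds, it is also open whether hydrogen in place of methyl reads the same in the chloro analogue, compound 2.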